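Urea Aryl Swap on the Shared Core

The source may hold more compounds than are shown below. What is called first, only, known or untested is meant among the compounds shown, and "the series" means these compounds.

Compound 1 `O=C(Nc1cccc(-n2cc(-c3ccncc3)c(-c3ccc(Cl)c(O)c3)n2)c1)Nc1cccc(C(F)(F)F)c1` gave > 32500 nM in a functional assay on HCC 2998 cells (Homo sapiens) for inhibition, read by sulforhodamine B assay, with a stated time of 48 h (a higher number here means a weaker inhibitor of growth, a lower number a stronger inhibitor of growth), which is a limit of the assay and not a number.
Compound 2 `COc1cc(-c2nn(-c3cccc(NC(=O)Nc4ccc(Cl)c(Cl)c4)c3)cc2-c2ccncc2)ccc1Cl` gave 6200 nM in this assay.

Compound 2 stands as the holder of the only number shown; the other value is a limit, at which one of the two values sits (the limit of > 32500 nM in this assay, at which 1 of the 2 values shown sits). Within the data shown here, compound 1 and compound 2 differ in two places, so their two values show only that compound 1 reaches the limit while compound 2 gives a number.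

Compound 3 `COc1cc(-c2nn(-c3cccc(NC(=O)Nc4cccc(C(F)(F)F)c4)c3)cc2-c2ccncc2)ccc1Cl` differs from compound 2 in one place: 3-(trifluoromethyl)phenyl in place of 3,4-dichlorophenyl on an amide-type nitrogen. Among the measured compounds shown here, no measured pair covers this change. The step from compound 2 to compound 3 is expected to be a modest weakening, a 1.6-fold higher number from compound 2 to compound 3 (0.21 log units; within the scatter), close to the scatter of the assay. Compound 3 is therefore estimated at 10000 nM, with a range from 4000 nM to 32500 nM.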

Compound 3, concentration for total growth inhibition: 3200 nM
Beside the measured number, compound 3's estimate is 3.1-fold (0.49 log units) above it, and the stated range ends above it.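

In this assay the group on the amide-type nitrogen can change without a readable shift: 3-(trifluoromethyl)phenyl in place of 3,4-dichlorophenyl gives a 1.9-fold lower number from compound 2 to compound 3 (0.29 log units; within the scatter) and so the two groups are not told apart here. Compound 3 also isolates the second difference within the first pair, since methyl in place of hydrogen on the oxygen on the aromatic ring gives an at least 10-fold lower number from compound 1 to compound 3 (1.00 log units; beyond the scatter) and is the only step shown that lies beyond the scatter. The value of compound 1 is a limit and not a number: the limit of > 32500 nM in this assay, at which 1 of the 3 values shown sits.

The compounds shown leave open how an ethyl group or a longer chain on that oxygen, or an amine in its place, would read in this assay on this core. They also leave open whether the same step holds with 3,4-dichlorophenyl on the amide-type nitrogen.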